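This account rests on a few compounds, and the source may have more. Where it says the series, first, only, none or still open, it means among the compounds named here.

Compound 1 `CC1=NN(c2ccccc2)C(=O)[C@@]12C(=O)C=CC[C@H]2c1cccc(C)c1` and compound 2 `CC1=NN(c2ccccc2)C(=O)[C@]12C(=O)C=CC[C@@H]2c1cccc(C)c1` form a mirror-image pair, and the starting point is the fact that compounds 1 and 2 differ only in the configuration as drawn. In a functional assay on A549 cells (Homo sapiens) for inhibition, read by MTT assay, with a stated time of 72 h (on this read-out lower numbers stand for stronger inhibition and higher numbers for weaker inhibition), compound 1 gives 3500 nM and compound 2 gives 4770 nM. The measured step is a 1.4-fold higher number from compound 1 to compound 2 (0.13 log units; within the scatter), so compound 2 stands level with its mirror image on these numbers.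

Compound 3 `CC1=NN(c2ccccc2)C(=O)[C@]12C(=O)C=CC[C@@H]2c1ccccc1` keeps the drawn configuration of compound 2 but has hydrogen in place of methyl on an aromatic carbon, turning 3-methylphenyl into phenyl: hydrogen in place of methyl on an aromatic carbon.

For the measured compounds named here, no measured step removes this methyl. The only one available, a 1.4-fold higher number from compound 1 to compound 2 (0.13 log units; within the scatter), changes configuration and leaves the substituent untouched, so it bears on the new change only indirectly. It shows that inverting both stereocentres produced no shift beyond the scatter, but it gives no direction for losing the methyl. With so little to go on, no change beyond the scatter is expected in this assay, and the uncertainty stays wide. The expected result is a 1.1-fold lower number from compound 2 to compound 3 (0.03 log units; within the scatter). For compound 3 the estimated value is 4500 nM, with an expected range of 1800 nM to 11000 nM.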

Compound 3, half-maximal inhibitory concentration: 9180 nM
The estimate for compound 3 lay 2.0-fold (0.31 log units) below the measured number; the measured number falls inside the stated range.
By their numbers in this assay, from the lowest: compounds 1, 2 and 3 (each within the scatter of the next, the first and the last beyond it).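

Turning 3-methylphenyl into phenyl gives, in this assay, a 1.9-fold higher number from compound 2 to compound 3 (0.28 log units; within the scatter), so in the drawn configuration of compound 2 the methyl can be replaced by hydrogen without a difference that stands clear of the scatter of repeated measurements. For the compounds shown here, this is the first direct reading at this aromatic position, as the earlier pair of compounds differed only in configuration and left the substituent unchanged. Nothing given here accounts for the size of this step, and the fact that the earlier pair are mirror images does not bear on it.

From the compounds shown here alone, compound 3 has a single partner in this comparison, so it remains open whether removing the methyl would give a similar result in the drawn configuration of compound 1. Also open, going by these compounds, is how this position would respond to a group other than methyl or hydrogen, such as a chlorine atom, a methoxy group, an amine or a carboxylic acid, and whether any such group would move the number beyond the scatter in either direction.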